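The source may report more compounds than this note shows. Statements on the series, on what has been measured and on what is new or still open speak of the compounds shown alone.

Working notes on the series. Compound 1 `COc1cc(-c2nn(-c3cccc(NC(=O)c4cccc(C(F)(F)F)c4)c3)cc2-c2ccncc2)ccc1Cl` is measured in a functional assay on Hs-578T cells (Homo sapiens) for inhibition, read by sulforhodamine B assay, with a stated time of 48 h (a lower number here means a stronger inhibitor of growth, a higher number a weaker inhibitor of growth), and gives 1070 nM, the higher of the two numbers recorded so far. Within the data shown here, compound 2 `O=C(Nc1cccc(-n2cc(-c3ccncc3)c(-c3ccc(Cl)c(O)c3)n2)c1)Nc1ccc(Cl)c(Cl)c1` gives 785 nM in this assay; the two values lie within the scatter of each other, so no order between compound 1 and compound 2 can be read from them, and since compound 2 differs from compound 1 in more than one place no single step is computed between them.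

Compound 3 `COc1cc(-c2nn(-c3cccc(NC(=O)Nc4cccc(C(F)(F)F)c4)c3)cc2-c2ccncc2)ccc1Cl` has not yet been measured. It differs from compound 1 by (3-(trifluoromethyl)phenyl)amino in place of 3-(trifluoromethyl)phenyl on a carbonyl carbon. Among the measured compounds shown here, no step between measured compounds isolates this change, so the expectation rests on the two values alone; a step of a 1.3-fold lower number from compound 1 to compound 3 (0.10 log units; within the scatter) is expected, that is, nothing beyond the scatter in either direction. Compound 3 is accordingly estimated at 850 nM in this assay, with a range from 300 nM to 2500 nM.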

Compound 3, concentration for 50% growth inhibition: 1230 nM
Compound 3: middle estimate off by 1.4-fold (0.16 log units), on the low side, and the stated range covers the measured number.
By their numbers in this assay, from the lowest: compounds 2, 1 and 3 (each within the scatter of the next).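

Among these compounds, on the carbonyl carbon whose other neighbour is an amide-type nitrogen, (3-(trifluoromethyl)phenyl)amino in place of 3-(trifluoromethyl)phenyl gives a 1.1-fold higher number from compound 1 to compound 3 (0.06 log units; within the scatter) in this assay and this is the first single-place reading for the series. The entering group adds a nitrogen and a hydrogen-bond donor, yet this pair shows no difference that the assay can resolve. No available evidence bears on this result, so it offers no explanation for it.

As far as these compounds go, whether this holds for other groups on the same carbonyl carbon, such as a morpholine or a short alkyl chain, remains open. Compound 2 differs from compound 3 in more than one place, so it cannot show whether the same change would read alike on a different core substitution.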